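Swapping One Five-Membered Ring for Another

The compounds below may be only part of what the source reports. "The series", "measured", "known", "first", "only" and "open" are said of these compounds alone.

Measured so far:
compound 1, `CC(C)(C)Cc1c(-c2ccc(F)cc2F)sc(N)c1C(=O)c1ccc(Cl)cc1`, giving 1%
compound 2, `Cc1noc(C)c1-c1sc(N)c(C(=O)c2ccc(Cl)cc2)c1CC(C)(C)C`, giving 1%
compound 3, `CC(C)(C)Cc1c(-c2ccsc2)sc(N)c1C(=O)c1ccc(Cl)cc1`, giving 4%

These three compounds share a common core and differ only in the aromatic group attached to one carbon of that core. The read-out is an assay on CHO cells for displacement of a labelled ligand from adenosine receptor A3 (Homo sapiens), read by scintillation counting, tested at 10 uM; a lower number here means less inhibition, a higher number more inhibition at the concentration tested (going by the name of the read-out). Compound 3 has the highest of the three numbers, but its nearest neighbour compound 1 sits only a number 3 percentage points higher from compound 1 to compound 3 (within the scatter), and compound 2 is equally close, a number 3 percentage points higher from compound 2 to compound 3 (within the scatter). All three values are therefore indistinguishable within the scatter, and none can be called stronger than another.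

Compound 4, `CC(C)(C)Cc1c(-c2ccco2)sc(N)c1C(=O)c1ccc(Cl)cc1`, has not yet been tested. It differs from compound 3 in one place: furan-2-yl in place of thiophen-3-yl on an aromatic carbon. The two earlier exchanges at this very position, from compound 1 to compound 3 and from compound 2 to compound 3, replaced one aromatic group by a quite different one and produced no step beyond the scatter. Two steps are a thin basis, but they point the same way. The expected step is therefore none beyond the scatter, a number 1 percentage points lower from compound 3 to compound 4 (within the scatter), and compound 4 is estimated at 3%, within a range from 0% to 12%.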

Compound 4, a percentage reported as inhibition, at one concentration (the size of the read-out at that concentration, not a potency): 1%
Compound 4: the middle estimate sits 2 percentage points above what was measured; the measured number falls inside the stated range.
By their numbers in this assay, from the lowest: compounds 1, 2, 4 and 3 (each within the scatter of the next).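

In this assay the furan-2-yl group, whose five-membered aromatic ring holds oxygen where thiophen-3-yl holds sulfur, gives a number 3 percentage points lower from compound 3 to compound 4 (within the scatter) and so adds a close exchange to the much broader ones seen earlier at this carbon. The comparisons with the other two groups read the same way, with no change at the digits printed from compound 2 to compound 4 (within the scatter) and no change at the digits printed from compound 1 to compound 4 (within the scatter) as the result, so all four aromatic groups on this carbon next to the ring sulfur now lie within the scatter of one another and none stands apart. Nothing measured alongside these compounds explains why the numbers stay so close together.

Still open, as far as these compounds go, is whether any group on this carbon would move the number beyond the scatter, for example a non-aromatic one such as a cyclohexyl ring, a primary amine or a carboxylic acid. Also open, from the compounds shown here alone, is whether the same flat picture would hold if the neopentyl group gave way to a longer chain, since every compound here carries that same neopentyl group.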